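Series notes: from compound 1 to compound 3

A few compounds are considered here, and "the series" means these few. Any claim that something is new, unique, unknown or untested is made for them only; others in the source may bear on it.

For the measured compounds named here, compound 1 `COC(=O)CO/N=C(\C)c1ccc(Cl)cc1` gives 24 mg/kg in a functional assay on the whole organism for inhibition, with Rattus norvegicus as the target, read by paw edema, with stated times of 1 h and 3 h (a higher number here means that more compound is needed for the effect, a lower number that less compound is needed), the lowest of the two numbers so far. Going by the values given here, compound 2 `C/C(=N\OCC(=O)OCCCCCCN(C)C)c1ccc(Cl)cc1` gives 66 mg/kg, and the one measured step, a 2.8-fold higher number from compound 1 to compound 2 (0.44 log units; beyond the scatter), changes a different place of the molecule. Compound 3 `CNC(=O)CO/N=C(\C)c1ccc(Cl)cc1` differs from compound 1 by methylamino in place of methoxy on a carbonyl carbon, methoxycarbonyl to methylcarbamoyl. Among the compounds with values here, no measured step touches the carbonyl carbon, so nothing bears directly on this change, and in this assay the expected step is within the scatter: a 1.3-fold higher number from compound 1 to compound 3 (0.10 log units; within the scatter). Compound 3 is therefore estimated at 30 mg/kg, in the range 12 mg/kg to 75 mg/kg.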

Compound 3, dose for half-maximal effect: 70 mg/kg
For compound 3 the middle estimate is 2.3-fold (0.37 log units) below the measured one, within the range that was stated.
By their numbers in this assay, from the lowest: compound 1; then compounds 2 and 3 (each within the scatter of the next).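

The carbonyl carbon is not a neutral place in this series: methylamino in place of methoxy gives a 2.9-fold higher number from compound 1 to compound 3 (0.46 log units; beyond the scatter), so this position responds to change in its own right. For the compounds shown here, this is the first reading at this carbon, as the earlier step lay elsewhere in the molecule. No measurement on hand accounts for the step.

Open, on these data alone, is how the carboxylic acid, the unsubstituted amide or ethoxy would read on the same carbonyl carbon. Dimethylamino, which has no amide hydrogen, would show whether that hydrogen goes with the step.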